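The compounds below may be only part of what the source reports. "The series", "measured", "known", "first", "only" and "open" are said of these compounds alone.

Measured so far:
compound 1, `CCCOc1cc(=O)oc2cc(OCc3ccccc3)ccc12`, in an assay on isolated protein (strain Sprague-Dawley) for inhibition of Amine oxidase [flavin-containing] A (Rattus norvegicus), read by spectrophotometry, with a stated time of 5 min, tested at 10 uM (on this read-out higher numbers stand for more inhibition at the one concentration tested (going by the name of the read-out) and lower numbers for less inhibition), gives 0%
compound 2, `COCOc1cc(=O)oc2cc(OCc3cccc(Cl)c3)ccc12`, in this assay gives 23%

Compound 2 stands highest of the two numbers in this assay; the nearest number is that of compound 1, which lies lower by a gap beyond the scatter. Going by the values given here, compound 1 and compound 2 differ in more than one place, so no single step between measured compounds can be read from them.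

Compound 3, `CNC(=O)COc1cc(=O)oc2cc(OCc3cccc(Cl)c3)ccc12`, has not yet been measured in this assay. It differs from compound 2 in one place: methylcarbamoyl in place of methoxy on a saturated chain carbon bound to an oxygen on an aromatic ring. Among the compounds with values here, no measured pair carries this change, so its size and direction have no precedent. Within the data shown here, with only two numbers to rest on, no step beyond the scatter is expected in either direction. Compound 3 is therefore expected to give about 25%, with a range from 0% to 55%. The step of a number 2 percentage points higher from compound 2 to compound 3 (within the scatter) that this estimate means is expected to stay within the scatter.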

Compound 3, a percentage reported as inhibition, at one concentration (the size of the read-out at that concentration, not a potency): 11%
For compound 3 the middle estimate is 14 percentage points above the measured one; measured number inside the range.
By their numbers in this assay, from the lowest: compound 1; then compound 3; then compound 2.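

In this assay, going by these compounds alone, methylcarbamoyl in place of methoxy on a saturated chain carbon bound to an oxygen on an aromatic ring gives the first step that can be read: a number 12 percentage points lower from compound 2 to compound 3 (beyond the scatter). The number at this position therefore responds to the group carried there, and going from methoxymethoxy to (methylcarbamoyl)methoxy, with the rest of the molecule unchanged, does not raise it. Nothing available explains the size or direction of this step.

As far as these compounds go, whether a carboxylic acid, an amine or a longer alkyl chain at the same place would read higher or lower remains open. Within the data shown here, also open is whether the step would hold on the unchlorinated benzyloxy scaffold of compound 1, since compound 1 differs from the other two compounds in more than one place and no step to it can be read.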